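One Ether Swap, Two Cores, One Estimate

This account rests on a few compounds, and the source may have more. Where it says the series, first, only, none or still open, it means among the compounds named here.

Compound 1 `c1cc(N2CCCCC2)nc(Nc2ccc(Oc3ncnc4sccc34)cc2)n1`: 64.8%
Compound 2 `CNC(=O)c1cc(Oc2ccc(Nc3nccc(N4CCCCC4)n3)cc2)ccn1`: 63.4%
Compound 3 `c1ccc2c(c1)CCN(c1ccnc(Nc3ccc(Oc4ncnc5sccc45)cc3)n1)C2`: 34%

These three compounds were tested in a functional assay on A549 cells (Homo sapiens) for inhibition, read by MTT assay, with a stated time of 72 h, tested at 20 uM; on this read-out higher numbers stand for more inhibition at the one concentration tested (going by the name of the read-out) and lower numbers for less inhibition. Compound 2 differs from compound 1 by a group of 10 heavy atoms (7 carbon, 2 nitrogen, 1 oxygen; one six-membered aromatic ring with 1 hetero atom) in place of a group of 9 heavy atoms (6 carbon, 2 nitrogen, 1 sulfur; one five-membered aromatic ring with 1 hetero atom, one six-membered aromatic ring with 2 hetero atoms), on an oxygen on an aromatic ring, and that change made a step of a number 1.4 percentage points lower from compound 1 to compound 2 (within the scatter). Compound 4 `CNC(=O)c1cc(Oc2ccc(Nc3nccc(N4CCc5ccccc5C4)n3)cc2)ccn1` has not yet been measured; it differs from compound 3 by a group of 10 heavy atoms (7 carbon, 2 nitrogen, 1 oxygen; one six-membered aromatic ring with 1 hetero atom) in place of a group of 9 heavy atoms (6 carbon, 2 nitrogen, 1 sulfur; one five-membered aromatic ring with 1 hetero atom, one six-membered aromatic ring with 2 hetero atoms), on an oxygen on an aromatic ring, the same change at the same kind of place. The two cores differ by 1,2,3,4-tetrahydroisoquinolin-2-yl in place of piperidin-1-yl on an aromatic carbon, a change that made a step of a number 30.8 percentage points lower from compound 1 to compound 3 (beyond the scatter). Because the earlier step of a number 1.4 percentage points lower from compound 1 to compound 2 (within the scatter) stayed within the scatter, the expected step from compound 3 to compound 4 is a number 1 percentage points lower from compound 3 to compound 4 (within the scatter), a step of about the same small size. Compound 4 is therefore estimated at 33%, most likely between 20% and 47%. Among the measured compounds shown here, only one earlier instance of this change is known, so the expectation is loose.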

Compound 4, a percentage reported as inhibition, at one concentration (the size of the read-out at that concentration, not a potency): 59.6%
Compound 4: the middle estimate sits 26.6 percentage points below what was measured; measured number outside the range, above it.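

Carried from the piperidin-1-yl compounds to the 1,2,3,4-tetrahydroisoquinolin-2-yl compounds, the change to 2-(methylcarbamoyl)pyridin-4-yl gave a number 25.6 percentage points higher from compound 3 to compound 4 (beyond the scatter), so the size of this step in this assay did not transfer from one core to the other: the same change on two cores in this assay, a number 1.4 percentage points lower (within the scatter) from compound 1 to compound 2 and a number 25.6 percentage points higher (beyond the scatter) from compound 3 to compound 4, 27 percentage points apart, beyond the scatter of two such steps. Read the other way, the exchange of piperidin-1-yl for 1,2,3,4-tetrahydroisoquinolin-2-yl gave a number 3.8 percentage points lower from compound 2 to compound 4 (within the scatter), so the effects of the two changes do not simply add up: the same change on two cores in this assay, a number 30.8 percentage points lower (beyond the scatter) from compound 1 to compound 3 and a number 3.8 percentage points lower (within the scatter) from compound 2 to compound 4, 27 percentage points apart, beyond the scatter of two such steps. These four compounds show that the two places depend on each other here, but they do not show why, or whether this holds for other groups.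

Going by these compounds, whether a morpholine on that aromatic carbon would follow compound 1 or compound 3 remains open. So does the effect of a carboxylic acid in place of the methylcarbamoyl group.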